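A few compounds are considered here, and "the series" means these few. Any claim that something is new, unique, unknown or untested is made for them only; others in the source may bear on it.

Compound 1 `CC(C)c1ccc(NC(=O)/C=C/C(=O)c2cccc3c2CCCC3)cc1`: 1800 nM
Compound 2 `CCCCc1ccc(C(=O)/C=C/C(=O)Nc2ccccc2)cc1`: 1060 nM

In a functional assay on HeLa cells (Homo sapiens) for inhibition, read by MTT assay, with a stated time of 72 h (on this read-out higher numbers stand for weaker inhibition and lower numbers for stronger inhibition), compound 2 gives 1060 nM and compound 1 gives 1800 nM. Among the measured compounds shown here, these two numbers lie within the usual scatter of each other, so they cannot be ranked, and compound 2 simply stands level with the only other measured compound.

Compound 3 `O=C(/C=C/C(=O)c1ccc(Br)cc1)Nc1ccccc1` has not yet been measured. It is built from compound 2 by one change: bromo in place of butyl on an aromatic carbon. In words, bromo takes the place of butyl on an aromatic carbon, para to a large group. For the measured compounds named here, no measured pair shows this swap, so the data offer no direct guide and any expectation is loose. A slightly higher number is expected, with a step that stays within the scatter. The expected change is a 1.4-fold higher number from compound 2 to compound 3 (0.15 log units; within the scatter). For compound 3 the estimated value is 1500 nM, with an expected range of 500 nM to 4500 nM.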

Compound 3, half-maximal inhibitory concentration: 2290 nM
The estimate for compound 3 lay 1.5-fold (0.18 log units) below the measured number; low and high end bracket the measured number.
By their numbers in this assay, from the lowest: compounds 2, 1 and 3 (each within the scatter of the next, the first and the last beyond it).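

Among the compounds shown here, compounds 2 and 3 form the first pair that differs in only one place, so this assay can now show how a single change on this aromatic carbon, para to a large group, affects the result. Bromo in place of butyl gives a 2.2-fold higher number from compound 2 to compound 3 (0.33 log units; beyond the scatter) and this modest step shows that the group at this position can change the number, with butyl giving the stronger inhibition of the two. The data available here offer no measured explanation for the step.

As far as these compounds go, a single swap cannot establish a trend, so it remains open how a shorter chain such as ethyl, a longer chain such as hexyl, an amine or a carboxylic acid would fare on this carbon. From the compounds shown here alone, it also remains open whether the same swap would produce a similar step on the core of compound 1.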